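The compounds below may be only part of what the source reports. "The series", "measured", "known", "first", "only" and "open" are said of these compounds alone.

Working notes on the dienone series

The four compounds share one core, a cross-conjugated dienone that carries a substituted phenyl ring at one end. Compound 1 `CC1=C(/C=C/C(=O)/C=C/c2ccc(Br)cc2)C(C)(C)CCC1` bears a bromo group, compound 2 `CC1=C(/C=C/C(=O)/C=C/c2ccc([N+](=O)[O-])cc2)C(C)(C)CCC1` a nitro group, compound 3 `CC1=C(/C=C/C(=O)/C=C/c2ccccc2[N+](=O)[O-])C(C)(C)CCC1` a nitro group at a different position, and compound 4 `CC1=C(/C=C/C(=O)/C=C/c2ccccc2Br)C(C)(C)CCC1` a bromo group at that same position.

In a functional assay on IMR-32 cells (Homo sapiens) for cytotoxicity, read by sulforhodamine B assay, with a stated time of 48 h (on this read-out higher numbers stand for weaker inhibition and lower numbers for stronger inhibition), compound 1 gives 10400 nM. Compound 2 gives 3200 nM in this assay. Compound 3 gives 13500 nM in this assay; against compound 1 this stands within the scatter, against compound 2 it lies beyond the scatter.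

The change from compound 2 to compound 1 is bromo in place of nitro on an aromatic carbon, and it made a step of a 3.3-fold higher number from compound 2 to compound 1 (0.51 log units; beyond the scatter). How the core of compound 3 differs from that of compound 2 is not broken down here; the two have the same atoms joined differently.

The change from compound 3 to compound 4 is bromo in place of nitro on an aromatic carbon. It is the same kind of change as that from compound 2 to compound 1, not the same: in the earlier pair the place is para to a large group, here it is ortho to a large group.

Compound 4 is expected to show a step of a 2.2-fold higher number from compound 3 to compound 4 (0.35 log units; beyond the scatter) in this assay. Among the compounds with values here, that expectation rests on the single earlier step of the same kind, a 3.3-fold higher number from compound 2 to compound 1 (0.51 log units; beyond the scatter). Within the data shown here, the place differs from that of the earlier pair, and no measured step at that place is known here, so the range is set wide. The estimate for compound 4 is 30000 nM, between 11000 nM and 80000 nM.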

Compound 4, half-maximal inhibitory concentration: 16300 nM
Beside the measured number, compound 4's estimate is 1.8-fold (0.26 log units) above it, and the stated range covers the measured number.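

Bromo in place of nitro on an aromatic carbon does not carry its size from one core to the other in this assay: the same change on two cores in this assay, a 3.3-fold higher number (0.51 log units; beyond the scatter) from compound 2 to compound 1 and a 1.2-fold higher number (0.08 log units; within the scatter) from compound 3 to compound 4, 2.7-fold (0.43 log units) apart, beyond the scatter of two such steps. On the core of compound 3, with the group ortho to a large group, the step is a 1.2-fold higher number from compound 3 to compound 4 (0.08 log units; within the scatter), so the two groups cannot be told apart at that place, and 2-bromophenyl in place of 4-bromophenyl gives a 1.6-fold higher number from compound 1 to compound 4 (0.20 log units; within the scatter), which also stays within the scatter. The step seen for one pair therefore cannot be taken over as a number for the other in this series, but two pairs do not show why they differ, and they give no rule for any other place on the ring or for any other replacement.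

On these data alone, it remains open whether an amine or a nitrile in place of nitro would follow the pair of compound 2 and compound 1 or the pair of compound 3 and compound 4. As far as these compounds go, it is also open whether a chloro group or a methoxy group at the same two places would show the same gap between the steps, and whether that gap would hold on a core with a longer chain.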